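This account rests on a few compounds, and the source may have more. Where it says the series, first, only, none or still open, it means among the compounds named here.

Measured in a functional assay on U-251 cells (Homo sapiens); a lower number here means a stronger inhibitor of growth, a higher number a weaker inhibitor of growth:
- compound 1 `O=S(=O)(/C=C/c1ccc(C(F)(F)F)cc1F)Cc1ccc(Nc2ncnc3ccccc23)cc1`: 100000 nM
- compound 2 `O=S(=O)(/C=C/c1ccc(C(F)(F)F)cc1F)Cc1ccc(Nc2ncnc3cc(Cl)ccc23)cc1`: > 100000 nM (a limit)

Compound 2 gives only a limit, > 100000 nM, and no number places it. Compound 3 `O=S(=O)(/C=C/c1ccc(F)cc1F)Cc1ccc(Nc2ncnc3cc(Cl)ccc23)cc1` keeps the chloro group and the rest of compound 2, and differs in one place: fluoro in place of trifluoromethyl on an aromatic carbon. This is fluoro in place of trifluoromethyl on an aromatic carbon, so 2-fluoro-4-(trifluoromethyl)phenyl becomes 2,4-difluorophenyl.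

For the measured compounds named here, only one measured step exists, a number no lower from compound 1 to compound 2 (the limit leaves the size open). It is a different change, chloro in place of hydrogen, and its size cannot be read. Going by the values given here, no measured step varies the trifluoromethyl group, so the data give no size or direction for this change in this assay. With nothing pointing to a shift, no step beyond the scatter is expected, and another limit is quite possible. The expected change is an at least 1.2-fold lower number from compound 2 to compound 3 (0.09 log units; that floor lies within the scatter). Compound 3 is estimated at 80000 nM, with an expected range of 15000 nM to 150000 nM.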

Compound 3, concentration for 50% growth inhibition: > 100000 nM
Compound 3: no number, only a limit; the forecaster's own chance of this, stated with the estimate: 55%; middle value at least 1.2-fold (0.09 log units) from the limit.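

In this assay compound 3 gives only a limit, > 100000 nM. Compound 2 also gives only a limit, so no step between compound 2 and compound 3 can be read: the limit of > 100000 nM in this assay, at which 2 of the 3 values shown sit.

Going by these compounds, whether fluoro in place of trifluoromethyl changes the read-out in this assay, and in which direction, stays open.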